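This account rests on a few compounds, and the source may have more. Where it says the series, first, only, none or still open, it means among the compounds named here.

Three compounds built on a shared core, in which a sulfonyl group carries an aryl-substituted amide nitrogen, have been tested in a functional assay on MCF7 cells (Homo sapiens) for antiproliferative activity, read by sulforhodamine B assay, with a stated time of 48 h; on this read-out higher numbers stand for weaker inhibition and lower numbers for stronger inhibition. Compound 3 `Cc1ccc(NS(=O)(=O)c2ccc(N3CCNC3=O)cc2)c(C)c1` gives 230 nM, which is the lowest of the three numbers. Compound 1 `Cc1ccccc1NS(=O)(=O)c1ccc(N2CCNC2=O)cc1` gives 280 nM, and the step of a 1.2-fold lower number from compound 1 to compound 3 (0.09 log units; within the scatter) lies within the scatter, so these two cannot be told apart. Compound 2 `COc1ccccc1NS(=O)(=O)c1ccc(N2CCNC2=O)cc1` gives 770 nM; the step of a 3.3-fold lower number from compound 2 to compound 3 (0.52 log units; beyond the scatter) is beyond the scatter, as is a 2.8-fold higher number from compound 1 to compound 2 (0.44 log units; beyond the scatter).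

Compound 4 `O=C1NCCN1c1ccc(S(=O)(=O)Nc2cccc(Cl)c2)cc1` has not been measured. It differs from compound 3 in one place: 3-chlorophenyl in place of 2,4-dimethylphenyl on a sulfonamide nitrogen. The step that bears most directly on this change is the earlier aryl swap on the same nitrogen, a 3.3-fold lower number from compound 2 to compound 3 (0.52 log units; beyond the scatter), which shows that the aryl group there can move the number by a modest amount in either direction. The steps of a 2.8-fold higher number from compound 1 to compound 2 (0.44 log units; beyond the scatter) and a 1.2-fold lower number from compound 1 to compound 3 (0.09 log units; within the scatter) show that a single substituent on that ring can matter or not at all. Going by the values given here, no measured compound carries a chlorine, so the direction is uncertain; a modest rise in the number is expected, a 1.7-fold higher number from compound 3 to compound 4 (0.24 log units; within the scatter). For compound 4 in this assay the estimated value is 400 nM, with a range from 150 nM to 1100 nM.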

Compound 4, half-maximal inhibitory concentration: 79 nM
The estimate for compound 4 lay 5.1-fold (0.70 log units) above the measured number, and the stated range ends above it.
By their numbers in this assay, from the lowest: compound 4; then compounds 3 and 1 (each within the scatter of the next); then compound 2.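

Placing 3-chlorophenyl on the sulfonamide nitrogen gives stronger inhibition than any of the earlier aryl groups in this assay, with a 2.9-fold lower number from compound 3 to compound 4 (0.46 log units; beyond the scatter), a 3.5-fold lower number from compound 1 to compound 4 (0.55 log units; beyond the scatter) and a 9.7-fold lower number from compound 2 to compound 4 (0.99 log units; beyond the scatter), all beyond the scatter, which makes compound 4 the strongest of the four. The earlier compounds shown here showed that changing this aryl group could set compound 2 apart from two compounds that could not be told apart, whereas this result shows that the same position can also yield a clear gain over those two, so the range at this position is wider than they revealed. Nothing measured here explains why this ring does better, so the gain remains an observation without a known cause.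

Going by these compounds alone, compound 4 is the only compound with a chlorine, and its ring differs from each earlier ring in more than one respect, so the contribution of the chlorine cannot be separated from that of the substituent pattern as a whole. As far as these compounds go, how a ring carrying a bromine, a nitrile or an amine would compare also remains open.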